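Bromo for Fluoro at the Fused Ring: a Forecast

This account rests on a few compounds, and the source may have more. Where it says the series, first, only, none or still open, it means among the compounds named here.

Measured so far:
compound 1, `O=C(CCCCCc1ccccc1)c1nc2cccc(F)c2o1`, gives > 10000 nM in an assay on HEK-293T cells for inhibition of diacylglycerol lipase-alpha (Homo sapiens), read by colorimetric assay; on this read-out lower numbers stand for stronger inhibition and higher numbers for weaker inhibition
compound 2, `O=C(CCCCCc1ccccc1)c1nc2ccc(Br)cc2o1`, gives 5890 nM in this assay

The value of compound 1 is a limit of this assay, not a number, which is what the limit of > 10000 nM in this assay, at which 1 of the 2 values shown sits, records. Compound 1 therefore stands at the weak end of what this assay can report. Compound 3, `O=C(CCCCCc1ccccc1)c1nc2cccc(Br)c2o1`, differs from compound 1 by bromo in place of fluoro on an aromatic carbon. Among the compounds with values here, no step between two measured compounds covers this exact change, so the direction is uncertain; a step beyond the scatter in either direction is not expected. Compound 3 is estimated at 8000 nM, between 3000 nM and 25000 nM, which means an expected step of an at least 1.2-fold lower number from compound 1 to compound 3 (0.09 log units; that floor lies within the scatter).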

Compound 3, half-maximal inhibitory concentration: > 10000 nM
Compound 3: only a limit was reported; the forecaster's own chance of this, stated with the estimate: 40%; middle value at least 1.2-fold (0.09 log units) away from the limit.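

Within the data shown here, compound 1 and compound 3 each carry only a limit, so no step between them can be read: the limit of > 10000 nM in this assay, at which 2 of the 3 values shown sit. On these data alone, whether bromo in place of fluoro on an aromatic carbon changes the result in this assay, and by how much, stays open.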